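A few compounds are considered here, and "the series" means these few. Any claim that something is new, unique, unknown or untested is made for them only; others in the source may bear on it.

Compound 1 `COc1ccc(N/C(CCNC2=CC(=O)c3ccccc3C2=O)=N\S(=O)(=O)c2ccc(C)cc2)cc1OC` — 12300 nM
Compound 2 `Cc1ccc(S(=O)(=O)/N=C(/CCNC2=CC(=O)c3ccccc3C2=O)Nc2ccc(Cl)cc2Cl)cc1` — 17000 nM

Both compounds were tested in a functional assay on MCF7 cells (Homo sapiens) for cytotoxicity, read by MTT assay, with a stated time of 48 h; on this read-out lower numbers stand for stronger inhibition and higher numbers for weaker inhibition. For the measured compounds named here, on these two numbers compound 2 stands highest, with compound 1 as its only neighbour; the step of a 1.4-fold higher number from compound 1 to compound 2 (0.14 log units; within the scatter) is within the scatter, so the two cannot be told apart.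

Compound 3 `COc1cc(N/C(CCNC2=CC(=O)c3ccccc3C2=O)=N\S(=O)(=O)c2ccc(C)cc2)cc(OC)c1OC` has not yet been measured in this assay. The change from compound 2 to compound 3 is 3,4,5-trimethoxyphenyl in place of 2,4-dichlorophenyl on an amine nitrogen. Going by the values given here, the only measured step that bears on this change is a 1.4-fold higher number from compound 1 to compound 2 (0.14 log units; within the scatter), which exchanged 3,4-dimethoxyphenyl for 2,4-dichlorophenyl on the same amine nitrogen and left the number within the scatter. Compound 3 carries 3,4,5-trimethoxyphenyl, closer in kind to compound 1 than to compound 2, so the expected step is a 1.4-fold lower number from compound 2 to compound 3 (0.15 log units; within the scatter), a slight move back toward the number of compound 1, not beyond the scatter. Compound 3 is therefore estimated at 12000 nM, with a range from 5000 nM to 30000 nM.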

Compound 3, half-maximal inhibitory concentration: 3050 nM
Estimate against measurement, compound 3: 3.9-fold (0.59 log units) above; the whole stated range lies above it.
By their numbers in this assay, from the lowest: compound 3; then compounds 1 and 2 (each within the scatter of the next).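

In this assay, the group on the amine nitrogen now has a clear effect on the number: replacing 2,4-dichlorophenyl with 3,4,5-trimethoxyphenyl gives a 5.6-fold lower number from compound 2 to compound 3 (0.75 log units; beyond the scatter), whereas the earlier exchange of 3,4-dimethoxyphenyl for 2,4-dichlorophenyl stayed within the scatter. The cleanest comparison is a 4.0-fold lower number from compound 1 to compound 3 (0.61 log units; beyond the scatter), as that pair differs only by methoxy in place of hydrogen on an aromatic carbon, so this single added group is enough to separate two otherwise identical compounds. The data shown offer no measurement that explains this shift.

The compounds shown leave open whether the gain depends on methoxy specifically, which an ethoxy or a hydroxy group on that same aromatic carbon would help to test. They also leave open whether the 3,4,5-trimethoxyphenyl group would keep its advantage on a changed core, such as one with a longer chain leading to the amine nitrogen.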